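This account rests on a few compounds, and the source may have more. Where it says the series, first, only, none or still open, it means among the compounds named here.

Of the compounds shown here, three built on one shared core have been tested, and they differ only in the group attached to the amide carbonyl. Compound 1 `COc1ccc(/C=C/c2cc(OC)cc(OC)c2/C=C/C(=O)NC2CC2)cc1` gives 10200 nM in a functional assay on B16-F10 cells (Mus musculus) for inhibition, read by MTT assay, with a stated time of 48 h; a higher number here means a weaker inhibitor, a lower number a stronger inhibitor. Compound 2 `CCNC(=O)/C=C/c1c(/C=C/c2ccc(OC)cc2)cc(OC)cc1OC` gives 6990 nM, and compound 3 `COc1ccc(/C=C/c2cc(OC)cc(OC)c2/C=C/C(=O)N2CCC(Cl)CC2)cc1` gives 4690 nM. Compound 3 stands lowest of the three numbers: the step of a 1.5-fold lower number from compound 2 to compound 3 (0.17 log units; within the scatter) is within the scatter, while the step of a 2.2-fold lower number from compound 1 to compound 3 (0.34 log units; beyond the scatter) is beyond it, though only modestly. The step of a 1.5-fold lower number from compound 1 to compound 2 (0.16 log units; within the scatter) is also within the scatter.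

Compound 4 `CCCCCN(CCCCC)C(=O)/C=C/c1c(/C=C/c2ccc(OC)cc2)cc(OC)cc1OC` keeps the same core and again changes only the amide side: dipentylamino in place of 4-chloropiperidin-1-yl on a carbonyl carbon. The two steps that bear on this, from compound 1 and from compound 2 to compound 3, were both small, so a change at this position is not expected to move the number far in either direction. The step of a 1.1-fold higher number from compound 3 to compound 4 (0.03 log units; within the scatter) is therefore expected to stay within the scatter. Compound 4 is estimated to give 5000 nM, in the range 2000 nM to 15000 nM.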

Compound 4, half-maximal inhibitory concentration: 9270 nM
Estimate against measurement, compound 4: 1.9-fold (0.27 log units) below, and the stated range covers the measured number.
By their numbers in this assay, from the lowest: compounds 3, 2, 4 and 1 (each within the scatter of the next, the first and the last beyond it).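

Replacing 4-chloropiperidin-1-yl with dipentylamino, which has no ring and more heavy atoms, gives in this assay a 2.0-fold higher number from compound 3 to compound 4 (0.30 log units; within the scatter), and the other two new steps, a 1.3-fold higher number from compound 2 to compound 4 (0.12 log units; within the scatter) and a 1.1-fold lower number from compound 1 to compound 4 (0.04 log units; within the scatter), also stay inside the scatter. The group on the carbonyl carbon can therefore be small, ring-bearing or carry long open chains with little effect on the number, since among these four compounds only the pair of compound 1 and compound 3 lies beyond the scatter. Nothing measured here offers a reason for this flat picture.

Going by these compounds, whether a group of another kind on the carbonyl carbon, such as a side chain ending in a free amine or a carboxylic acid, would leave this narrow band stays open. So does whether changes to the shared core would move the number further than changes on the amide side.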